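A Second Methoxy Group on Compound 1

This account rests on a few compounds, and the source may have more. Where it says the series, first, only, none or still open, it means among the compounds named here.

In a physicochemical assay, read by spectrophotometry, with a stated time of 30 min (on this read-out lower numbers stand for stronger inhibition and higher numbers for weaker inhibition), compound 1 `COc1cc(/C=C/C(=O)NC2CCN(Cc3ccccc3)CC2)ccc1O` gives 32500 nM. Going by the values given here, the only other measured compound, compound 2 `O=C(/C=C/c1ccc(O)cc1)NC1CCN(Cc2ccccc2)CC1`, gives 980000 nM, so compound 1 holds the lower of the two numbers and is the stronger inhibitor of this pair. The two differ in one place, and replacing the methoxy group with hydrogen gives a 30-fold higher number from compound 1 to compound 2 (1.48 log units; beyond the scatter), a large step beyond the scatter.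

Compound 3 `COc1cc(/C=C/C(=O)NC2CCN(Cc3ccccc3)CC2)cc(OC)c1O` makes a change in the opposite sense: methoxy in place of hydrogen on an aromatic carbon. The new methoxy group sits on an aromatic carbon, ortho to a hydroxy group and meta to a methoxy group. Among the compounds with values here, only that one measured step bears on this change, and a single pair cannot show whether a second methoxy group would repeat what the first one did. A lower number is therefore expected in this assay, by a smaller margin than the measured step. The expected change is a 2.3-fold lower number from compound 1 to compound 3 (0.37 log units; beyond the scatter). For compound 3 the estimate is 14000 nM, with an expected range of 5000 nM to 36000 nM.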

Compound 3, half-maximal inhibitory concentration: 22300 nM
Compound 3: middle estimate off by 1.6-fold (0.20 log units), on the low side; the measured number falls inside the stated range.
By their numbers in this assay, from the lowest: compounds 3 and 1 (each within the scatter of the next); then compound 2.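

In this assay, placing a second methoxy group on this aromatic carbon, ortho to a hydroxy group and meta to the first methoxy group, gives a 1.5-fold lower number from compound 1 to compound 3 (0.16 log units; within the scatter), so the numbers for compound 1 and compound 3 cannot be told apart in this assay. The existing methoxy group of compound 1 behaves very differently: replacing it with hydrogen gives a 30-fold higher number from compound 1 to compound 2 (1.48 log units; beyond the scatter), so the large step seen at that place does not reappear when a methoxy group enters at this new place. No measurement is available that would explain why these two steps differ so much in size.

From the compounds shown here alone, it remains open whether a different group on this same aromatic carbon, such as an amine, a carboxylic acid or a longer chain, would move the number beyond the scatter. All three compounds also carry the hydroxy group, so their numbers say nothing about how a compound with a chlorine atom or an amine in its place would read.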